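The compounds below may be only part of what the source reports. "The series", "measured", "known", "first", "only" and "open" are said of these compounds alone.

In a functional assay on T47D cells (Homo sapiens) for cytotoxicity, read by CCK-8 assay (on this read-out higher numbers stand for weaker inhibition and lower numbers for stronger inhibition), the three measured compounds stand as follows.
Compound 1, `Oc1cccc(-c2cc(-c3cccs3)cc(-c3ccccc3O)n2)c1`, reaches only a limit of the assay: > 50000 nM.
Compound 2, `Oc1cccc(-c2cc(-c3ccco3)cc(-c3ccccc3O)n2)c1`, gives 820 nM.
Compound 3, `Oc1ccc(-c2cc(-c3ccco3)cc(-c3ccccc3O)n2)cc1`, also reaches only a limit: > 50000 nM.

Going by the values given here, compound 2 thus holds the only actual number in the set; the other two values are limits, and the limit of > 50000 nM in this assay, at which 2 of the 3 values shown sit, marks where both of them sit. The two recorded steps are both large: an at least 60-fold lower number from compound 1 to compound 2 (1.78 log units; beyond the scatter), where furan-2-yl stands in place of thiophen-2-yl, and an at least 60-fold higher number from compound 2 to compound 3 (1.78 log units; beyond the scatter), where 4-hydroxyphenyl stands in place of 3-hydroxyphenyl. Compound 4, `Oc1cccc(-c2cc(-c3ccoc3)cc(-c3ccccc3O)n2)c1`, differs from compound 2 in one place: furan-3-yl in place of furan-2-yl on an aromatic carbon. Neither measured step touches the position of the oxygen within the furan ring, so neither bears directly on this change. Both do show that small alterations to this core can shift the number beyond the scatter, and compound 2 already carries the strongest value shown, so a move in the direction of weaker inhibition seems the more likely outcome, with a real chance that only a limit is reported. Compound 4 is expected at 5000 nM, with a range from 800 nM to 50000 nM. This estimate corresponds to an expected step of a 6.1-fold higher number from compound 2 to compound 4 (0.79 log units; beyond the scatter).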

Compound 4, half-maximal inhibitory concentration: > 50000 nM
Compound 4 was reported as a limit; the forecaster's own chance of this, stated with the estimate: 35%; at least 10-fold (1.00 log units) between middle value and limit.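

Joining the furan to the core through a different ring carbon, with the same atoms and the same counted donors and acceptors, gives an at least 60-fold higher number from compound 2 to compound 4 (1.78 log units; beyond the scatter). The earlier steps shown here swapped thiophen-2-yl for furan-2-yl or 3-hydroxyphenyl for 4-hydroxyphenyl, whereas this one shows that in this assay, at the position opposite the ring nitrogen, the point of attachment of the furan ring alone is enough to separate compound 2 from the limit. Compound 4 now joins compound 1 and compound 3 at the same limit, so the step from compound 1 to compound 4 cannot be read, and how much weaker any of these three is remains unknown: the limit of > 50000 nM in this assay, at which 3 of the 4 values shown sit.

Of the groups shown at this position, only furan-2-yl gives a number, and compound 3 shows that it does not do so with 4-hydroxyphenyl in place of 3-hydroxyphenyl, so the furan-2-yl result cannot be taken as a rule for the series. On these data alone, whether a different group at this position, such as a pyridyl ring, a thiazolyl ring or an amine, would also give a number stays open.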